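Moving the ring methyl in a pyrazole-based reductase inhibitor

This account rests on a few compounds, and the source may have more. Where it says the series, first, only, none or still open, it means among the compounds named here.

Measured compounds:
Compound 1, `CC(C)c1c(C(=O)NCc2ccccc2)nn(-c2ccc(F)cc2)c1OC[C@@H](O)C[C@@H](O)CC(=O)O` — 3.8 nM
Compound 2, `Cc1ccc(CNC(=O)c2nn(-c3ccc(F)cc3)c(OC[C@@H](O)C[C@@H](O)CC(=O)O)c2C(C)C)cc1` — 15 nM

In an assay on microsomes from liver for inhibition of 3-hydroxy-3-methylglutaryl-coenzyme A reductase (Rattus norvegicus) (a lower number here means a stronger inhibitor, a higher number a weaker inhibitor), compound 1 gives 3.8 nM, and compound 2 gives 15 nM, the higher of the two numbers. Within the data shown here, the only step among them, a 3.9-fold higher number from compound 1 to compound 2 (0.60 log units; beyond the scatter), shows that adding a methyl to the benzyl ring weakens inhibition modestly.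

Compound 3, `Cc1cccc(CNC(=O)c2nn(-c3ccc(F)cc3)c(OC[C@@H](O)C[C@@H](O)CC(=O)O)c2C(C)C)c1`, keeps that methyl but places it differently: 3-methylphenyl in place of 4-methylphenyl on a saturated chain carbon bound to an amide-type nitrogen. Among the measured compounds shown here, no measured step covers moving a methyl around this ring; the step from compound 1 to compound 2 only says that its presence costs something. Compound 3 is therefore expected to sit near compound 2, perhaps a little toward compound 1, with a step of a 1.5-fold lower number from compound 2 to compound 3 (0.18 log units; within the scatter) in this assay. The estimate for compound 3 is 10 nM, within a range of 3 nM to 30 nM.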

Compound 3, half-maximal inhibitory concentration: 4.9 nM
Compound 3: middle estimate off by 2.0-fold (0.31 log units), on the high side, and the stated range covers the measured number.
By their numbers in this assay, from the lowest: compounds 1 and 3 (each within the scatter of the next); then compound 2.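

Moving the methyl from 4-methylphenyl to 3-methylphenyl, on the same saturated chain carbon bound to an amide-type nitrogen, gives a 3.1-fold lower number from compound 2 to compound 3 (0.49 log units; beyond the scatter) in this assay, so the cost seen earlier for the methyl depends on where it sits on the ring. The other new step, a 1.3-fold higher number from compound 1 to compound 3 (0.11 log units; within the scatter), lies within the scatter, so 3-methylbenzyl cannot be told apart from the plain benzyl group in this assay, whereas 4-methylbenzyl can. Nothing available bears on why the two placements of the methyl differ.

On these data alone, whether a methoxy group or a chlorine atom in place of the methyl of 3-methylbenzyl would also stay level with the plain benzyl group remains open. So does whether an ethyl group there would be tolerated in the same way.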